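The source may hold more compounds than are shown below. What is called first, only, known or untested is meant among the compounds shown, and "the series" means these compounds.

Measured so far:
compound 1, `CSCCCON1C(=O)[C@@H](NC(=O)OCCCCC2CCCCC2)[C@@H]1C`: 167 nM
compound 2, `CC(=O)CCCON1C(=O)[C@@H](NC(=O)OCCCCC2CCCCC2)[C@@H]1C`: 75 nM
compound 3, `C[C@H]1[C@H](NC(=O)OCCCCC2CCCCC2)C(=O)N1OCCCCc1ccccc1`: 1240 nM

All three share one core, an amide-type nitrogen in a ring that carries an oxygen, and they differ only in the group on that oxygen. In an assay on HEK293 cells for inhibition of N-acylethanolamine-hydrolyzing acid amidase (Homo sapiens), read by fluorescence, with stated times of 10 min and 50 min (on this read-out higher numbers stand for weaker inhibition and lower numbers for stronger inhibition), compound 3 gives the highest number of the three: a 7.4-fold higher number from compound 1 to compound 3 (0.87 log units; beyond the scatter) and a 17-fold higher number from compound 2 to compound 3 (1.22 log units; beyond the scatter), so compound 3 is the weakest inhibitor here. Within the chain-bearing pair, a 2.2-fold lower number from compound 1 to compound 2 (0.35 log units; beyond the scatter).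

Compound 4, `C[C@H]1[C@H](NC(=O)OCCCCC2CCCCC2)C(=O)N1Oc1ccccc1S(C)(=O)=O`, has not been measured. It differs from compound 3 in one place: 2-(methylsulfonyl)phenyl in place of 4-phenylbutyl on an oxygen. Within the data shown here, no measured step swaps a chain for a ring attached directly to that oxygen, so the three steps bear on this change only loosely. What they do show is that, on this oxygen, the two chains carrying an oxygen-bearing or sulfur-bearing group gave lower numbers than the 4-phenylbutyl group of compound 3. On that basis a lower number than compound 3 is expected for compound 4, a step of a 4.1-fold lower number from compound 3 to compound 4 (0.62 log units; beyond the scatter) in this assay, with wide uncertainty. The estimate for compound 4 is 300 nM, with a range from 50 nM to 2000 nM.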

Compound 4, half-maximal inhibitory concentration: 6 nM
For compound 4 the middle estimate is 50-fold (1.70 log units) above the measured one; measured number outside the range, below it.
By their numbers in this assay, from the lowest: compound 4; then compound 2; then compound 1; then compound 3.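

The 2-(methylsulfonyl)phenyl group on this oxygen gives a 210-fold lower number from compound 3 to compound 4 (2.32 log units; beyond the scatter), and it also outdoes the other two chains, with a 13-fold lower number from compound 2 to compound 4 (1.10 log units; beyond the scatter) and a 28-fold lower number from compound 1 to compound 4 (1.44 log units; beyond the scatter). Compound 4 is therefore the strongest inhibitor of the four, and its gain over compound 3 is larger than the widest gap among the chains, a 17-fold higher number from compound 2 to compound 3 (1.22 log units; beyond the scatter), so the chains gave little hint of how much this position can change the number. Nothing available here explains the gain.

On these data alone, this swap places a ring directly on the oxygen and adds a methylsulfonyl group in one step, so the share of each remains open. A plain phenyl on this oxygen would help separate the two, and a phenyl carrying an amine or a carboxylic acid in place of methylsulfonyl would test how specific that group is.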